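The compounds below may be only part of what the source reports. "The series", "measured", "known", "first", "only" and "open" are said of these compounds alone.

In an assay on CHO-K1 cells for displacement of a labelled ligand from 5-hydroxytryptamine receptor 6 (Homo sapiens), read by scintillation counting, with a stated time of 3 h (a lower number here means a stronger inhibitor, a higher number a weaker inhibitor), compound 1 `O=C1CC(c2ccccc2)CN1c1ccc2c(c1)CCNCC2` gives 54 nM, compound 2 `Clc1ccccc1C1CCN(c2ccc3c(c2)CCNCC3)C1` gives 650 nM, and compound 3 `O=C1OC(c2ccccc2)CN1c1ccc2c(c1)CCNCC2` gives 16 nM. Compound 3 therefore stands lowest of the three numbers, separated from compound 1 and from compound 2 by gaps that lie beyond the usual scatter, so it is the strongest inhibitor among them. Compound 4 `COc1ccccc1C1CN(c2ccc3c(c2)CCNCC3)C(=O)O1` differs from compound 3 by methoxy in place of hydrogen on an aromatic carbon. Going by the values given here, no measured pair in this set shows that change, so its effect is not known from these data. The step from compound 3 to compound 4 is expected to be small, a 1.3-fold higher number from compound 3 to compound 4 (0.10 log units; within the scatter), and not beyond the scatter of this assay. Compound 4 is expected to give about 20 nM, between 6 nM and 65 nM.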

Compound 4, inhibition constant: 87 nM
Compound 4: middle estimate off by 4.4-fold (0.64 log units), on the low side; the measured number lies above the stated range.
By their numbers in this assay, from the lowest: compound 3; then compounds 1 and 4 (each within the scatter of the next); then compound 2.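

In this assay the change from phenyl to 2-methoxyphenyl gives a 5.4-fold higher number from compound 3 to compound 4 (0.74 log units; beyond the scatter) and so counts as a real weakening. Going by these compounds alone, this is the first single-place step in the set, and it shows that methoxy in place of hydrogen on this aromatic carbon, ortho to a large group, is not neutral here. Nothing available accounts for the loss.

Going by these compounds, whether a fluorine atom or a hydroxyl at this place would bring the same loss stays open. So does whether methoxy on another carbon of that ring would.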